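Swapping the aryl amine in a cytotoxicity series

The compounds below may be only part of what the source reports. "The series", "measured", "known", "first", "only" and "open" are said of these compounds alone.

Compound 1 `CCS(=O)(=O)Nc1cc(-c2ccc3ncnc(Nc4ccc(F)cc4)c3c2)cnc1OC`: 7620 nM
Compound 2 `CCS(=O)(=O)Nc1cc(-c2ccc3ncnc(Nc4ccc(C(=O)OC)c(OC)c4)c3c2)cnc1OC`: 3350 nM

In a functional assay on A549 cells (Homo sapiens) for cytotoxicity, read by sulforhodamine B assay, with a stated time of 72 h (on this read-out lower numbers stand for stronger inhibition and higher numbers for weaker inhibition), compound 1 gives 7620 nM, the highest of the two numbers shown; the nearest is compound 2 with 3350 nM, a step of a 2.3-fold lower number from compound 1 to compound 2 (0.36 log units; beyond the scatter). Compound 3 `CCS(=O)(=O)Nc1cc(-c2ccc3ncnc(Nc4ccc(OC)nc4)c3c2)cnc1OC` differs from compound 1 by 6-methoxypyridin-3-yl in place of 4-fluorophenyl on a nitrogen on an aromatic ring. Going by the values given here, no measured step exchanges 4-fluorophenyl for 6-methoxypyridin-3-yl, so the single step of a 2.3-fold lower number from compound 1 to compound 2 (0.36 log units; beyond the scatter) is only a loose guide, and it was modest. The expected step is a 1.3-fold lower number from compound 1 to compound 3 (0.10 log units; within the scatter), within the usual scatter. The estimate for compound 3 is 6000 nM, ranging from 2500 nM to 15000 nM.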

Compound 3, half-maximal inhibitory concentration: 5560 nM
Beside the measured number, compound 3's estimate is 1.1-fold (0.03 log units) above it; the range from low to high includes it.
By their numbers in this assay, from the lowest: compounds 2, 3 and 1 (each within the scatter of the next, the first and the last beyond it).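

In this assay, placing 6-methoxypyridin-3-yl on a nitrogen on an aromatic ring gives a 1.4-fold lower number from compound 1 to compound 3 (0.14 log units; within the scatter) and a 1.7-fold higher number from compound 2 to compound 3 (0.22 log units; within the scatter) against the other two compounds. A ring with a hetero atom can therefore replace the carbon-only ring of compound 1 without a change that stands out from the scatter, and compound 3 also cannot be separated from compound 2. Nothing available gives a reason for these small steps. Going by these compounds, whether a ring bearing a carboxylic acid or an amine at this position would move the number further remains open.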